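Pyrrolidine for Dimethylamine on a Thioether-Linked Chain

The source may hold more compounds than are shown below. What is called first, only, known or untested is meant among the compounds shown, and "the series" means these compounds.

Compound 1 `O=C(CC1c2ccccc2N=C(SCCCCCN2CCCC2)N1c1ccc(-c2ccc(F)cc2)cc1)NCc1ccc(F)cc1`: 4880 nM
Compound 2 `CN(C)CCCCCSC1=Nc2ccccc2C(CC(=O)NCc2ccccc2)N1c1ccccc1`: 13800 nM
Compound 3 `CN(C)CCCCCSC1=Nc2ccccc2C(CC(=O)NCc2ccc(F)cc2)N1c1ccc(-c2ccc(F)cc2)cc1`: 2760 nM

Three compounds were measured in an assay on cells for inhibition of Voltage-dependent T-type calcium channel subunit alpha-1H (Homo sapiens), read by patch clamp; on this read-out higher numbers stand for weaker inhibition and lower numbers for stronger inhibition. Compound 2 has the highest number of the three, and the difference between its core and that of compound 3 is not broken down here. From compound 3 to compound 1 the change was pyrrolidin-1-yl in place of dimethylamino on a saturated chain carbon, five bonds along the chain from a sulfur, and the step was a 1.8-fold higher number from compound 3 to compound 1 (0.25 log units; within the scatter).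

Compound 4 `O=C(CC1c2ccccc2N=C(SCCCCCN2CCCC2)N1c1ccccc1)NCc1ccccc1` has not yet been measured in this assay. It differs from compound 2 by pyrrolidin-1-yl in place of dimethylamino on a saturated chain carbon, five bonds along the chain from a sulfur, the same kind of change, at the same place, as that between compound 3 and compound 1. Because the earlier step was a 1.8-fold higher number from compound 3 to compound 1 (0.25 log units; within the scatter), a step of comparable size is expected here, namely a 1.3-fold higher number from compound 2 to compound 4 (0.12 log units; within the scatter). On that basis compound 4 is estimated at 18000 nM, expected to fall between 7000 nM and 45000 nM.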

Compound 4, half-maximal inhibitory concentration: 7710 nM
The estimate for compound 4 lay 2.3-fold (0.37 log units) above the measured number; the measured number falls inside the stated range.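

Moved to the other core, pyrrolidin-1-yl in place of dimethylamino gave a 1.8-fold lower number from compound 2 to compound 4 (0.25 log units; within the scatter) in this assay. Set side by side, the two steps do not agree, so the step on one core cannot simply be carried over to the other: the same change on two cores in this assay, a 1.8-fold higher number (0.25 log units; within the scatter) from compound 3 to compound 1 and a 1.8-fold lower number (0.25 log units; within the scatter) from compound 2 to compound 4, 3.2-fold (0.50 log units) apart, beyond the scatter of two such steps Each step alone stays within the scatter, so neither shows a real effect of the change on its own core, and two pairs do not show which part of the cores lies behind the gap.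

The compounds shown leave open how a piperidine or a morpholine would read in place of either amine. They also leave open whether a shorter chain would keep these numbers on either core.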